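Bromo in place of hydrogen on compound 2

The compounds below may be only part of what the source reports. "The series", "measured", "known", "first", "only" and "open" are said of these compounds alone.

Of the compounds shown here, two on the shared core have been read in a functional assay on SK-OV-3 cells (Homo sapiens) for antiproliferative activity, read by MTT assay, with a stated time of 72 h (on this read-out higher numbers stand for weaker inhibition and lower numbers for stronger inhibition), so far. Compound 1 (`O=C(CCc1cccc2c1B(O)OC2)NCc1ccccc1`) gives > 100000 nM here, which is a limit and not a number. Within the data shown here, compound 2 (`Cc1ccc(NC(=O)CCc2cccc3c2B(O)OC3)cc1`) gives 860 nM as the only true number so far. Among the measured compounds shown here, the one measured step is an at least 110-fold lower number from compound 1 to compound 2 (2.06 log units; beyond the scatter) and it is large, with 4-methylphenyl in place of benzyl on an amide-type nitrogen.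

Compound 3 (`Cc1ccc(NC(=O)CCc2cccc3c2B(O)OC3)cc1Br`) differs from compound 2 by one change (bromo in place of hydrogen on an aromatic carbon), bromo in place of hydrogen on an aromatic carbon. The measured step bears on this only loosely, since it exchanged the group on the nitrogen and did not test any addition to the aromatic ring. Its size therefore does not carry over. In this assay no step beyond the scatter is expected, and no direction can be argued with confidence. The estimated change is a 1.4-fold lower number from compound 2 to compound 3 (0.16 log units; within the scatter) and stays within the scatter. For compound 3 the expected value is 600 nM with an estimated range from 150 nM to 2500 nM on this read-out.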

Compound 3, half-maximal inhibitory concentration: 600 nM
For compound 3 middle estimate and measured number coincide at the digits printed; low and high end bracket the measured number.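

The step from compound 2 to compound 3 moves the change away from the group on the amide-type nitrogen and onto the six-membered aromatic ring itself, at a carbon ortho to a methyl group and meta to a large group, and in this assay it reads as a 1.4-fold lower number from compound 2 to compound 3 (0.16 log units; within the scatter) on bromo in place of hydrogen. This position therefore accepts one added heavy atom, a bromine, and compound 2 and compound 3 read alike on this assay, so the sensitivity seen at the amide-type nitrogen does not appear at this carbon for this one change. Nothing in the supporting data bears on this result, and no reason for it can be offered.

The compounds shown do not tell whether this carbon accepts groups other than bromo, such as fluoro, methoxy, an amine or a carboxylic acid, or whether the neighbouring methyl group is needed for bromo to be accepted. They also leave open how a longer chain between the amide carbonyl and the shared core would read on the ring-substituted compounds.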